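This account rests on a few compounds, and the source may have more. Where it says the series, first, only, none or still open, it means among the compounds named here.

Compound 2 `CCOc1ccc2c(Cl)ccnc2c1` gives 3160 nM in a functional assay on HCT-116 cells (Homo sapiens) for cytotoxicity, read by MTT assay, with a stated time of 48 h (on this read-out higher numbers stand for weaker inhibition and lower numbers for stronger inhibition), the higher of the two numbers in hand; the gap to compound 1 `C=CCOc1ccc2c(NCCN(C)C)ccnc2c1`, which gives 860 nM in this assay, lies beyond the scatter. Compound 3 `CCOc1ccc2c(NCCN(C)C)ccnc2c1` is still to be measured in this assay. Its change from compound 2 is (2-(dimethylamino)ethyl)amino in place of chloro on an aromatic carbon. Within the data shown here, no measured pair shows this exact change, but compound 1 carries the same entering group on the same type of core and gives 860 nM in this assay. A step toward stronger inhibition, a 3.2-fold lower number from compound 2 to compound 3 (0.50 log units; beyond the scatter), is therefore expected. For compound 3 the estimate is 1000 nM, with a range from 400 nM to 2500 nM.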

Compound 3, half-maximal inhibitory concentration: 2570 nM
The estimate for compound 3 lay 2.6-fold (0.41 log units) below the measured number, outside the stated range (above it).
By their numbers in this assay, from the lowest: compound 1; then compounds 3 and 2 (each within the scatter of the next).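

In this assay, (2-(dimethylamino)ethyl)amino in place of chloro on the aromatic carbon opposite the ring nitrogen gives a 1.2-fold lower number from compound 2 to compound 3 (0.09 log units; within the scatter), so this exchange alone does not separate the two compounds. The step that does register lies on the oxygen side chain: methyl in place of vinyl gives a 3.0-fold higher number from compound 1 to compound 3 (0.48 log units; beyond the scatter), a modest change. No measurement at hand explains either step.

As far as these compounds go, whether the vinyl-to-methyl step also holds with chloro on the core remains open. So does the effect of a longer chain on the oxygen or of morpholine in place of the (2-(dimethylamino)ethyl)amino group.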